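The source may hold more compounds than are shown below. What is called first, only, known or untested is meant among the compounds shown, and "the series" means these compounds.

The three measured compounds share one core, seen in compound 1 `CCN(CC)c1cc2[nH]c(C3CCCCC3)nc2cc1NC(=O)OCCOCCOC`, compound 2 `CCCCOC(=O)Nc1cc2nc(C3CCCCC3)[nH]c2cc1N(CC)CCN(C)C` and compound 3 `CCCN(CCC)c1cc2[nH]c(C3CCCCC3)nc2cc1NC(=O)OCc1ccccc1`. In an ADME assay on Vero cells (Chlorocebus sabaeus) for cytotoxicity, read by resazurin assay, with a stated time of 3 days (a higher number here means a weaker inhibitor, a lower number a stronger inhibitor), compound 1 reaches only a limit, > 100 ug/mL. Compound 2 likewise reaches only a limit, > 100 ug/mL. Compound 3 also stops at a limit, > 100 ug/mL. Among the compounds with values here, compound 2 therefore stands where every value here stands, at the limit of > 100 ug/mL in this assay, at which 3 of the 3 values shown sit, and no step between measured compounds can be drawn. Compound 4 `CCCCOC(=O)Nc1cc2nc(C3CCCCC3)[nH]c2cc1N(CC)CCN(CC)CC` differs from compound 2 in one place: diethylamino in place of dimethylamino on a saturated chain carbon, two bonds along the chain from a nitrogen on an aromatic ring. Within the data shown here, no measured step separates the two, and no change beyond the scatter is expected in this assay. The expected step of a number no higher from compound 2 to compound 4 (the limit leaves the size open) is nothing beyond the scatter. Compound 4 is estimated at 100 ug/mL, between 50 ug/mL and 200 ug/mL, most likely again as a limit.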

Compound 4, half-maximal inhibitory concentration: > 50 ug/mL
Compound 4: only a limit was reported (the forecaster's own chance of this, stated with the estimate: 85%); the middle value lies beyond the limit too.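

In this assay compound 2 gives only a limit, > 100 ug/mL. Compound 4 also gives only a limit, > 50 ug/mL, so no step can be read between the two. The compounds shown leave open the actual half-maximal inhibitory concentration of each.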